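Removing the Propyl Group from the Side Chain of Compound 1

The compounds below may be only part of what the source reports. "The series", "measured", "known", "first", "only" and "open" are said of these compounds alone.

For the measured compounds named here, in a functional assay on L1210 cells (Mus musculus) for cytotoxicity (on this read-out higher numbers stand for an effect only at larger amounts of compound and lower numbers for an effect already at smaller amounts), compound 1 `CCCC(O)C1=CC(=O)c2c(OC)ccc(OC)c2C1=O` gives 0.409 ug/mL, the highest of the three numbers known so far. Compound 3 `CCC(O)c1cc(OC)c2c(c1OC)C(=O)C=CC2=O` gives 0.085 ug/mL and compound 2 `CCCCCC(O)c1cc(OC)c2c(c1OC)C(=O)C=CC2=O` gives 0.066 ug/mL in this assay, both lower than compound 1 by more than the scatter. Compound 4 `COc1ccc(OC)c2c1C(=O)C=C(CO)C2=O` arises from compound 1 by hydrogen in place of propyl on a saturated chain carbon bound to a double-bonded ring carbon and an oxygen on a saturated carbon. Going by the values given here, the only measured step of the same kind is a 1.3-fold higher number from compound 2 to compound 3 (0.11 log units; within the scatter), where the propyl is likewise taken off a saturated chain carbon carrying an oxygen. On that basis no step beyond the scatter is expected in either direction, and a 1.0-fold lower number from compound 1 to compound 4 (0.01 log units; within the scatter) is the estimated change. Compound 4 is accordingly expected to give 0.4 ug/mL, within a range from 0.15 ug/mL to 1.1 ug/mL.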

Compound 4, concentration for half-maximal effect: 0.524 ug/mL
Estimate against measurement, compound 4: 1.3-fold (0.12 log units) below, within the range that was stated.
By their numbers in this assay, from the lowest: compounds 2 and 3 (each within the scatter of the next); then compounds 1 and 4 (each within the scatter of the next).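

In this assay, taking the propyl off this saturated chain carbon, so that 1-hydroxybutyl becomes hydroxymethyl, gives a 1.3-fold higher number from compound 1 to compound 4 (0.11 log units; within the scatter). On the core of compound 1, this shortening of the chain thus produces no change that can be told from the scatter. The one earlier step of this kind now has a counterpart on a second core, and the two agree: the same change on two cores in this assay, a 1.3-fold higher number (0.11 log units; within the scatter) from compound 2 to compound 3 and a 1.3-fold higher number (0.11 log units; within the scatter) from compound 1 to compound 4, 1.0-fold (0.00 log units) apart, within the scatter of two such steps

On these data alone, all four compounds keep the oxygen on this saturated chain carbon, and what an amine in its place would do remains open. Also open, as far as these compounds go, is the effect of a chain longer than 1-hydroxybutyl on the core of compound 1.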